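Sulfonate ester series: swapping the sulfonyl aryl group

A few compounds are considered here, and "the series" means these few. Any claim that something is new, unique, unknown or untested is made for them only; others in the source may bear on it.

Measured so far:
- compound 1, `N#C/C(=C\c1ccccc1OS(=O)(=O)c1ccccc1[N+](=O)[O-])C(=O)Nc1nnc(Cc2ccccc2)s1`: 10%
- compound 2, `N#C/C(=C\c1ccccc1OS(=O)(=O)c1ccc(F)cc1)C(=O)Nc1nnc(Cc2ccccc2)s1`: 6%
- compound 3, `N#C/C(=C\c1ccccc1OS(=O)(=O)c1ccccc1[N+](=O)[O-])C(=O)Nc1nnc(Cc2cccc(F)c2)s1`: "not toxic" (no number reported) (no number given)

Four compounds share one core. In an ADME assay on HEK-293T cells (Homo sapiens) for inhibition, read by CCK-8 assay, with a stated time of 48 h, tested at 20 uM (on this read-out higher numbers stand for more inhibition of growth at the one concentration tested and lower numbers for less inhibition of growth), compound 1 gives 10% and compound 2 gives 6%. Compound 3 is recorded in this assay only as "not toxic" (no number reported), so no number stands for it. Compound 4, `N#C/C(=C\c1ccccc1OS(=O)(=O)c1ccc(F)cc1)C(=O)Nc1nnc(Cc2cccc(F)c2)s1`, is still to be measured in this assay.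

The change from compound 1 to compound 2 is 4-fluorophenyl in place of 2-nitrophenyl on a sulfonyl sulfur. Its step is a number 4 percentage points lower from compound 1 to compound 2 (within the scatter). The change from compound 3 to compound 4 is 4-fluorophenyl in place of 2-nitrophenyl on a sulfonyl sulfur, the same change at the same place. The two cores differ by fluoro in place of hydrogen on an aromatic carbon.

Within the data shown here, the one measured instance of this change moved the read-out by an amount that stays within the scatter, so for compound 4 a step of about the same size is expected from compound 3, on the basis that the change from compound 1 to compound 2 gave a number 4 percentage points lower from compound 1 to compound 2 (within the scatter). Compound 3 carries no number, only a statement of no toxicity, and both measured compounds sit low, so compound 4 is expected to sit low as well. The estimate for compound 4 in this assay is 5%, expected to fall between -5% and 15%. There is a fair chance that compound 4, like compound 3, is reported only as not toxic without a number.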

Compound 4, percent growth inhibition at one concentration: 17%
Estimate against measurement, compound 4: 12 percentage points below; the measured number lies above the stated range.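

In this assay the swap to 4-fluorophenyl in place of 2-nitrophenyl on a sulfonyl sulfur can be followed in one core only, with a number 4 percentage points lower from compound 1 to compound 2 (within the scatter), while the matching step in the core of compound 3 and the fluoro step between compound 1 and compound 3 cannot be read, as compound 3 is recorded as not toxic and carries no number. The step that can be read concerns the core rather than the swap: with 4-fluorophenyl on the sulfonyl sulfur, fluoro in place of hydrogen on an aromatic carbon gives a number 11 percentage points higher from compound 2 to compound 4 (beyond the scatter), so the two cores are not interchangeable here, at least for this one pair. Whether the swap itself carries from one core to the other remains unshown, and nothing available accounts for the step.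

Among these compounds, open is whether fluoro in place of hydrogen gives a similar step with 2-nitrophenyl on the sulfonyl sulfur, since the series offers no pair of numbers for that comparison. Also open, as far as these compounds go, is how this assay would respond to an amine or a carboxylic acid on the phenyl group on the sulfonyl sulfur, in place of the fluoro or the nitro group.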